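The compounds below may be only part of what the source reports. "The series", "measured", "known", "first", "only" and "open" are said of these compounds alone.

Of the compounds shown here, three built on one shared core have been measured so far. Compound 1 `O=C(NCC1CCC(F)(F)CC1)c1c(Cl)ccc2ncccc12` gives 230 nM in an assay on HEK293 cells for antagonist activity at P2X purinoceptor 7 (Homo sapiens), read by fluorescence, with stated times of 20 min and 30 min; on this read-out lower numbers stand for stronger inhibition and higher numbers for weaker inhibition. Compound 2 `O=C(NCC1CCC(F)(F)CC1)c1c(Cl)ccc2nc(C3=CCCC3)ccc12` gives 36 nM in this assay, and compound 3 `O=C(NCC1CCC(F)(F)CC1)c1c(Cl)ccc2nc(NCCO)ccc12` gives 72 nM. Compound 3 thus stands second highest of the three numbers, with a 2.0-fold higher number from compound 2 to compound 3 (0.30 log units; within the scatter) and a 3.2-fold lower number from compound 1 to compound 3 (0.50 log units; beyond the scatter). Compound 4 `O=C(NCC1CCC(F)(F)CC1)c1c(Cl)ccc2nc(C3CCCC3)ccc12` differs from compound 3 by cyclopentyl in place of (2-hydroxyethyl)amino on an aromatic carbon. The step most relevant here is a 2.0-fold higher number from compound 2 to compound 3 (0.30 log units; within the scatter), which exchanged the same (2-hydroxyethyl)amino for another five-membered carbon ring; a 6.4-fold lower number from compound 1 to compound 2 (0.81 log units; beyond the scatter) points the same way. A small move toward a lower number is therefore expected, about a 1.8-fold lower number from compound 3 to compound 4 (0.26 log units; within the scatter). Compound 4 is estimated at 40 nM, within a range of 15 nM to 110 nM.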

Compound 4, half-maximal inhibitory concentration: 94 nM
Estimate against measurement, compound 4: 2.4-fold (0.37 log units) below; low and high end bracket the measured number.
By their numbers in this assay, from the lowest: compounds 2, 3 and 4 (each within the scatter of the next, the first and the last beyond it); then compound 1.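

On the carbon next to the ring nitrogen, the step from an open chain with a hydroxyl to a ring of carbon only gives a 1.3-fold higher number from compound 3 to compound 4 (0.12 log units; within the scatter) and so separates these two groups by no more than the scatter. Losing the ring double bond counts for more, with cyclopentyl in place of cyclopent-1-en-1-yl giving a 2.6-fold higher number from compound 2 to compound 4 (0.42 log units; beyond the scatter), while cyclopentyl in place of hydrogen still gives a 2.4-fold lower number from compound 1 to compound 4 (0.39 log units; beyond the scatter). Nothing available explains these differences.

Still open, going by these compounds, is how a longer chain, a primary amine or a carboxylic acid would fare on this carbon. On these data alone, whether a six-membered carbon ring behaves like cyclopentyl is also open.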